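A Methyl Added to a Compound at Zero

This account rests on a few compounds, and the source may have more. Where it says the series, first, only, none or still open, it means among the compounds named here.

Within the data shown here, in an in vivo ADME assay on the whole organism (Rattus norvegicus) for pharmacokinetics (a lower number here means that a smaller share of the oral dose reaches the circulation, a higher number that a larger share of the oral dose reaches the circulation), compound 2 (`N#Cc1cc(F)ccc1C1CCN(CCCNC(=O)C2=CNC(=O)N[C@@H]2c2ccc(F)c(F)c2)CC1`) gives 0% and holds the only exact number so far. Compound 1 (`CC1=C(C(=O)NCCCN2CCC(c3ccc(F)cc3)CC2)[C@@H](c2ccc(F)c(F)c2)NC(=O)N1`) has only a limit as its result, < 6% in this assay and no exact number.

Compound 3 (`CC1=C(C(=O)NCCCN2CCC(c3ccc(F)cc3C#N)CC2)[C@@H](c2ccc(F)c(F)c2)NC(=O)N1`) departs from compound 2 by a single change, (methyl in place of hydrogen on a double-bonded ring carbon), which puts methyl in place of hydrogen on a double-bonded ring carbon. Among the measured compounds shown here, no measured pair shows what this swap alone does to this assay in these compounds. Only a small upward move is expected, since compound 2 at 0% has no room to fall. The expected change is modest, a number 5 percentage points higher from compound 2 to compound 3 (within the scatter), and stays within the usual scatter of such measurements. For compound 3 the estimated oral bioavailability is 5%, with an expected range from 0% to 15%.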

Compound 3, oral bioavailability: 0%
Beside the measured number, compound 3's estimate is 5 percentage points above it; the measured number falls inside the stated range.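

In this assay, putting methyl in place of hydrogen on a double-bonded ring carbon brings no change at the digits printed from compound 2 to compound 3 (within the scatter). Among these compounds, this is the first measured pair for this swap, and it shows that a single added carbon at this position is not enough to lift the compound off the bottom of the scale. The step between compound 1 and compound 3, which adds cyano in place of hydrogen on an aromatic carbon, cannot be read because compound 1 carries a limit and not a number: the limit of < 6% in this assay, at which 1 of the 3 values shown sits.

As far as these compounds go, both compounds of the readable pair sit at the bottom of the scale, so it remains open what methyl does here in a compound with a measurable share of the oral dose in the circulation. From the compounds shown here alone, it also remains open whether a larger group on this ring carbon, such as ethyl, or an amine would give a different reading.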